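The compounds below may be only part of what the source reports. "The series", "measured", "known", "first", "only" and "open" are said of these compounds alone.

Measured so far:
compound 1 `C=C1C[C@]23C[C@@]1(O)CC[C@H]2c1ccc(OS(=O)(=O)c2ccc(C)cc2)c(C)c1[C@@H]3Cn1cc(-c2ccc(Br)cc2)nn1`; compound 2 `C=C1C[C@]23C[C@@]1(O)CC[C@H]2c1ccc(OS(=O)(=O)c2ccc(C)cc2)c(C)c1[C@@H]3Cn1cc(-c2ccc(OC)cc2)nn1`; compound 3 `C=C1C(=O)[C@]23C[C@@]1(O)CC[C@H]2c1ccc(O)c(C)c1[C@@H]3Cn1cc(-c2ccc(OC)cc2)nn1`.

In a functional assay on SW480 cells (Homo sapiens) for cytotoxicity, read by MTT assay, with a stated time of 4 days (a lower number here means a stronger inhibitor, a higher number a weaker inhibitor), compound 1 gives only a limit of the assay, > 20000 nM. In this assay compound 2 likewise reaches only a limit, > 20000 nM. In this assay compound 3 gives 220 nM. From compound 2 to compound 1 the change is bromo in place of methoxy on an aromatic carbon, and that step, a step that the two limits leave unreadable from compound 2 to compound 1, cannot be sized because of the limit of > 20000 nM in this assay, at which 2 of the 3 values shown sit. The difference between the cores of compound 3 and compound 2 is not broken down here. Compound 4 `C=C1C(=O)[C@]23C[C@@]1(O)CC[C@H]2c1ccc(O)c(C)c1[C@@H]3Cn1cc(-c2ccc(Br)cc2)nn1` stands to compound 3 as compound 1 stands to compound 2: the change is bromo in place of methoxy on an aromatic carbon, the same change. Since the earlier step is unreadable, the expected step of a 1.4-fold higher number from compound 3 to compound 4 (0.13 log units; within the scatter) in this assay rests only on the value of compound 3, 220 nM, and is taken as small. Compound 4 is therefore estimated at 300 nM, between 80 nM and 1500 nM.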

Compound 4, half-maximal inhibitory concentration: 310 nM
The estimate for compound 4 lay 1.0-fold (0.01 log units) below the measured number; measured number inside the range.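

In this assay, replacing 4-methoxyphenyl with 4-bromophenyl gives a 1.4-fold higher number from compound 3 to compound 4 (0.15 log units; within the scatter), so on this core the two compounds cannot be told apart. The same change on the other core, from compound 2 to compound 1, cannot be read, because both compounds sit at a limit of the assay: the limit of > 20000 nM in this assay, at which 2 of the 4 values shown sit. The swap is therefore seen to make no clear difference on one core only, and nothing shows that it would behave alike on the other.

The compounds shown leave open how other groups would fare in place of the methoxy or bromo group, such as an amine, a carboxylic acid or a longer chain.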